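This account rests on a few compounds, and the source may have more. Where it says the series, first, only, none or still open, it means among the compounds named here.

Of the compounds shown here, two have so far been tested in a functional assay on L1210 cells (Mus musculus) for inhibition, read by cell counting, with a stated time of 2 days; on this read-out higher numbers stand for weaker inhibition and lower numbers for stronger inhibition. Compound 2 `C=C(Br)C(=O)Nc1cccc(-c2cn3nc(-c4ccc(C)cc4)sc3n2)c1` gives 920 nM in this assay. Compound 1 `COc1ccc(-c2nn3cc(-c4cccc(N)c4)nc3s2)cc1OC` gives 16000 nM in this assay. Of these two numbers, compound 2 holds the lower one, and its gap to compound 1 lies well beyond the scatter of repeated measurements, so compound 2 is the stronger inhibitor of the pair. The two compounds differ in several places at once, so no single change can be tied to that gap.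

Compound 3 `C=C(Br)C(=O)Nc1cccc(-c2cn3nc(Cc4ccc(OC)cc4)sc3n2)c1` has not yet been measured. It keeps the whole of compound 2 apart from one group: 4-methoxybenzyl in place of 4-methylphenyl on an aromatic carbon. Among the measured compounds shown here, no measured pair shows what such a change does here, so the direction is uncertain; a small step, perhaps a slight weakening, is expected, a 1.6-fold higher number from compound 2 to compound 3 (0.21 log units; within the scatter). Compound 3 is therefore estimated to give 1500 nM in this assay, with a range from 450 nM to 5000 nM.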

Compound 3, half-maximal inhibitory concentration: 1400 nM
Beside the measured number, compound 3's estimate is 1.1-fold (0.03 log units) above it; low and high end bracket the measured number.
By their numbers in this assay, from the lowest: compounds 2 and 3 (each within the scatter of the next); then compound 1.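

In this assay the exchange of 4-methylphenyl for 4-methoxybenzyl gives a 1.5-fold higher number from compound 2 to compound 3 (0.18 log units; within the scatter) on this aromatic carbon of the five-membered ring, so the read-out does not separate the two compounds. Among the compounds shown here, this is the first pair that differs in one place only, and it shows that a group of 9 heavy atoms with a hydrogen-bond acceptor can replace one of 7 heavy atoms with none, while the number stays within the usual scatter. No measured evidence here explains this result.

The exchange alters two things together, the carbon link to the aromatic ring and the group at the far end of that ring, so the pair cannot say what either does alone, or whether a group of another kind, such as an amine or a carboxylic acid, would fit on this carbon. Also open, from the compounds shown here alone, is what separates compound 1 from the other two, since the amine on its phenyl ring and the group on its five-membered ring are never exchanged one at a time.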